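Swapping the aryl group on the hydrazone carbon

The source may report more compounds than this note shows. Statements on the series, on what has been measured and on what is new or still open speak of the compounds shown alone.

Going by the values given here, compound 2 `CN(C)CCn1cnnc1-c1cc(Oc2ccc(NC(=O)N/N=C/c3cc(Br)c(O)c(Br)c3)cc2F)ccn1` gives 2670 nM in a functional assay on HT-29 cells (Homo sapiens) for cytotoxicity, read by MTT assay, with a stated time of 72 h (on this read-out lower numbers stand for stronger inhibition and higher numbers for weaker inhibition), the higher of the two numbers measured so far. Compound 1 `CN(C)CCn1cnnc1-c1cc(Oc2ccc(NC(=O)N/N=C/c3ccc(O)c(O)c3)cc2F)ccn1` gives 1890 nM in this assay, and the change a 1.4-fold higher number from compound 1 to compound 2 (0.15 log units; within the scatter) is too small to count as a real difference. Compound 3 `COc1cc(/C=N/NC(=O)Nc2ccc(Oc3ccnc(-c4nncn4CCN(C)C)c3)c(F)c2)ccc1O` is made from compound 2 by the change (4-hydroxy-3-methoxyphenyl in place of 3,5-dibromo-4-hydroxyphenyl on a carbon with a double bond to nitrogen). Among the compounds with values here, only that one step bears on this change, and it stayed within the scatter, so no step beyond the scatter is expected for a 1.3-fold lower number from compound 2 to compound 3 (0.13 log units; within the scatter). Compound 3 is therefore estimated at 2000 nM, with a range from 900 nM to 4500 nM.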

Compound 3, half-maximal inhibitory concentration: 120 nM
Compound 3: the middle estimate sits 17-fold (1.22 log units) above what was measured; the whole stated range lies above it.
By their numbers in this assay, from the lowest: compound 3; then compounds 1 and 2 (each within the scatter of the next).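

The aryl group on the carbon with a double bond to nitrogen clearly matters: in this assay, 4-hydroxy-3-methoxyphenyl in place of 3,5-dibromo-4-hydroxyphenyl gives a large drop (a 22-fold lower number from compound 2 to compound 3 (1.35 log units; beyond the scatter)), although the earlier swap stayed within the scatter. A single methyl on one ring oxygen is enough for a similar drop (a 16-fold lower number from compound 1 to compound 3 (1.20 log units; beyond the scatter)). Nothing measured here explains this drop. The compounds shown leave open whether ethoxy in place of the methoxy group would keep the lower number, and whether an amine there would do the same.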